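The source may hold more compounds than are shown below. What is called first, only, known or untested is meant among the compounds shown, and "the series" means these compounds.

Three compounds have been measured in an assay on cells for inhibition of Voltage-dependent T-type calcium channel subunit alpha-1I (Homo sapiens), read by patch clamp; a higher number here means a weaker inhibitor, a lower number a stronger inhibitor:

compound 1 `CN(C)CCCCCSC1=Nc2ccccc2C(CC(=O)NCc2ccccc2)N1c1ccc(-c2ccccc2)cc1` gives 1760 nM
compound 2 `O=C(CC1c2ccccc2N=C(SCCCCCN2CCCC2)N1c1ccc(-c2ccc(F)cc2)cc1)NCc1ccc(F)cc1` gives 19800 nM
compound 3 `O=C(CC1c2ccccc2N=C(SCCCCCN2CCCC2)N1c1ccc(-c2ccc(F)cc2)cc1)NCc1ccccc1` gives 5100 nM

Compound 1 gives the lowest number of the three, compound 3 a higher one, and compound 2 the highest. How the core of compound 1 differs from the core of compound 3 is not broken down here. Within the pair that shares a core, the change fluoro in place of hydrogen on an aromatic carbon brought a 3.9-fold higher number from compound 3 to compound 2 (0.59 log units; beyond the scatter).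

Compound 4 `CN(C)CCCCCSC1=Nc2ccccc2C(CC(=O)NCc2ccc(F)cc2)N1c1ccc(-c2ccccc2)cc1` has not been measured. It differs from compound 1 by fluoro in place of hydrogen on an aromatic carbon, the same change at a place described in the same words. The step from compound 1 to compound 4 is therefore expected to be a 3.4-fold higher number from compound 1 to compound 4 (0.53 log units; beyond the scatter), an expectation that rests on a 3.9-fold higher number from compound 3 to compound 2 (0.59 log units; beyond the scatter). Compound 4 is estimated to give 6000 nM, likely between 2500 nM and 15000 nM.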

Compound 4, half-maximal inhibitory concentration: 6100 nM
Beside the measured number, compound 4's estimate is 1.0-fold (0.01 log units) below it, within the range that was stated.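

In this assay, changing benzyl to 4-fluorobenzyl on compound 1 gave a 3.5-fold higher number from compound 1 to compound 4 (0.54 log units; beyond the scatter). Set beside the earlier case, the change behaved alike on the two cores: the same change on two cores in this assay, a 3.9-fold higher number (0.59 log units; beyond the scatter) from compound 3 to compound 2 and a 3.5-fold higher number (0.54 log units; beyond the scatter) from compound 1 to compound 4, 1.1-fold (0.05 log units) apart, within the scatter of two such steps. This shows that the weakening carried over from one core to the other, but two cores cannot show that it would hold on every core in the series, or for fluoro placed elsewhere.

The compounds shown leave open whether a chloro or a methoxy group in place of this fluoro would raise the number to a similar extent. They also leave open whether the same step would appear with a shorter chain carrying the amine.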